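The compounds below may be only part of what the source reports. "The series", "measured", "known", "first", "only" and "open" are said of these compounds alone.

The compounds share one core, shown in compound 1 `COc1cc2c(Oc3ccc(NC(=O)N/N=C/c4ccc(C(F)(F)F)cc4)cc3F)ccnc2cc1OCCCN1CCCC1`. In a functional assay on MDA-MB-231 cells (Homo sapiens) for cytotoxicity, read by MTT assay, with a stated time of 72 h (a lower number here means a stronger inhibitor, a higher number a weaker inhibitor), compound 1 gives 1800 nM. Compound 2 `COc1cc2c(Oc3ccc(NC(=O)N/N=C/c4ccc(OC(F)(F)F)cc4)cc3F)ccnc2cc1OCCCN1CCCCC1` differs from it in more than one place, and in this assay compound 2 gives 820 nM. The two differ in several places at once. Only what the two values show is said here, namely that both fall in the same general region of the read-out. Compound 3 `COc1ccc(/C=N/NC(=O)Nc2ccc(Oc3ccnc4cc(OCCCN5CCCCC5)c(OC)cc34)c(F)c2)c(OC)c1` stands apart from these on the numbers: in this assay compound 3 is reported only as "not determined" (no result reported), with no single number, and it offers no anchor of its own.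

The step to compound 4 `COc1cc2c(Oc3ccc(NC(=O)N/N=C/c4cccs4)cc3F)ccnc2cc1OCCCN1CCCCC1` is a single change on the terminal group, (thiophen-2-yl in place of 2,4-dimethoxyphenyl on a carbon with a double bond to nitrogen), that is, thiophen-2-yl in place of 2,4-dimethoxyphenyl on a carbon with a double bond to nitrogen. Going by the values given here, no measured pair maps this step, and compound 3 gives nothing to measure it against. In this assay the step from compound 3 to compound 4 is expected to be small, with no clear direction beyond the usual scatter. Resting on compound 2, whose value is 820 nM, compound 4 is estimated at 1000 nM, within a range from 300 nM to 4000 nM.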

Compound 4, half-maximal inhibitory concentration: 1260 nM
The estimate for compound 4 lay 1.3-fold (0.10 log units) below the measured number; the range from low to high includes it.
By their numbers in this assay, from the lowest: compounds 2, 4 and 1 (each within the scatter of the next, the first and the last beyond it).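

At the terminal group on a carbon with a double bond to nitrogen, this assay now offers a measured pair that differs in one place: thiophen-2-yl in place of 4-(trifluoromethoxy)phenyl gives a 1.5-fold higher number from compound 2 to compound 4 (0.19 log units; within the scatter), so the two values cannot be told apart and this change shows no clear effect on the read-out. The pair thus shows that this place can carry a five-membered aromatic ring with 1 hetero atom and still give a value in the same region as compound 2, while the step from 2,4-dimethoxyphenyl cannot be read, as compound 3 has no number. Nothing measured here bears on why the two values lie so close.

This single pair leaves open whether a quite different group at this place, such as an amine or a carboxylic acid, would move the number beyond the scatter. It also leaves open whether thiophen-2-yl would give a similar result on the core of compound 1, which differs from compound 2 in several places at once.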